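Chloro to Bromo: A Small Halogen Swap

The source may hold more compounds than are shown below. What is called first, only, known or untested is meant among the compounds shown, and "the series" means these compounds.

Three compounds share one core and differ only in the aromatic group attached to a ring nitrogen. Compound 1 `CC1(C)[C@H]2CC[C@]1(C)N(Cc1cn(-c3cccc(C#N)c3)nn1)C(=O)C2` carries 3-cyanophenyl, compound 2 `CC1(C)[C@H]2CC[C@]1(C)N(Cc1cn(-c3ccccc3Cl)nn1)C(=O)C2` carries 2-chlorophenyl and compound 3 `CC1(C)[C@H]2CC[C@]1(C)N(Cc1cn(-c3cccc(Cl)c3)nn1)C(=O)C2` carries 3-chlorophenyl. In a functional assay on PANC-1 cells (Homo sapiens) for inhibition, read by MTT assay, with a stated time of 24 h (on this read-out higher numbers stand for weaker inhibition and lower numbers for stronger inhibition), compound 1 gives 260 nM, compound 2 gives 270 nM and compound 3 gives 260 nM. Going by the values given here, the steps of a 1.0-fold higher number from compound 1 to compound 2 (0.02 log units; within the scatter), no change at the digits printed from compound 1 to compound 3 (within the scatter) and a 1.0-fold lower number from compound 2 to compound 3 (0.02 log units; within the scatter) all lie within the scatter, so on these three numbers compound 3 sits level with compound 1 and no compound stands apart from the others.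

Compound 4 `CC1(C)[C@H]2CC[C@]1(C)N(Cc1cn(-c3cccc(Br)c3)nn1)C(=O)C2` differs from compound 3 in one place: bromo in place of chloro on an aromatic carbon. Among the compounds with values here, no measured step exchanges one halogen for another, so the nearest guides are the replacement of cyano by chloro and the exchange of 2-chlorophenyl for 3-chlorophenyl, both of which left the number unchanged, as seen in no change at the digits printed from compound 1 to compound 3 (within the scatter) and a 1.0-fold lower number from compound 2 to compound 3 (0.02 log units; within the scatter). The step of no change at the digits printed from compound 3 to compound 4 (within the scatter) is therefore expected to stay within the scatter, with no direction favoured. In this assay compound 4 is estimated at 260 nM, with a range from 150 nM to 450 nM.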

Compound 4, half-maximal inhibitory concentration: 90 nM
Beside the measured number, compound 4's estimate is 2.9-fold (0.46 log units) above it; the whole stated range lies above it.
By their numbers in this assay, from the lowest: compound 4; then compounds 1, 3 and 2 (each within the scatter of the next).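

In this assay the earlier changes to the aromatic group left the number unmoved, but 3-bromophenyl in place of 3-chlorophenyl gives a 2.9-fold lower number from compound 3 to compound 4 (0.46 log units; beyond the scatter) and so shows that this position can respond to a change. The other two comparisons agree, with a 2.9-fold lower number from compound 1 to compound 4 (0.46 log units; beyond the scatter) and a 3.0-fold lower number from compound 2 to compound 4 (0.48 log units; beyond the scatter), so among these four compounds only compound 4 stands apart, and a single halogen exchange on an aromatic carbon separates it where cyano and chloro at that place did not separate. Nothing measured here accounts for this difference.

On these data alone, it remains open whether iodo on the same carbon would lower the number further, or whether fluoro would raise it. A methyl or methoxy group there, or 2-bromophenyl, would show whether the lower number is specific to bromo at this position.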